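The compounds below may be only part of what the source reports. "The series", "measured", "known", "first", "only" and "open" are said of these compounds alone.

Compounds measured so far in a functional assay on A549 cells (Homo sapiens) for antiproliferative activity, read by MTT assay; a lower number here means a stronger inhibitor, a higher number a weaker inhibitor:
- compound 1, `O=C1N=C(N2CCC[C@H]2C(=O)Nc2ccc3ncnc(Nc4cccc(Cl)c4)c3c2)S/C1=C/c1ccc(Br)s1`: in this assay compound 1 reports only a limit, > 50000 nM.
- compound 2, `O=C1N=C(N2CCC[C@H]2C(=O)Nc2ccc3ncnc(Nc4cccc(Cl)c4)c3c2)S/C1=C/c1cccc(Cl)c1`: in this assay compound 2 likewise reports only a limit, > 50000 nM.
- compound 3, `O=C1N=C(N2CCC[C@H]2C(=O)Nc2ccc3ncnc(Nc4cccc(Cl)c4)c3c2)S/C1=C/c1cccs1`: in this assay compound 3 gives 6100 nM.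

Among the measured compounds shown here, compound 3 therefore carries the only actual number in this set; the other two readings sit at the limit of > 50000 nM in this assay, at which 2 of the 3 values shown sit, so they tell nothing beyond that ceiling. The next compound, compound 4, `O=C1N=C(N2CCC[C@H]2C(=O)Nc2ccc3ncnc(Nc4cccc(Cl)c4)c3c2)S/C1=C/c1ccc2ccccc2n1`, is built from compound 3 by one change: quinolin-2-yl in place of thiophen-2-yl on a double-bonded chain carbon bound to a double-bonded ring carbon.

For the measured compounds named here, two measured steps touch the same position. Going from compound 2 to compound 3 gave an at least 8.1-fold lower number from compound 2 to compound 3 (0.91 log units; beyond the scatter), and going from compound 1 to compound 3 gave an at least 8.1-fold lower number from compound 1 to compound 3 (0.91 log units; beyond the scatter). Both steps show that the plain thiophen-2-yl group at this position is the only variant so far that yields a readable number, while the larger 3-chlorophenyl and the brominated thiophene fall at the limit. Quinolin-2-yl is larger again than either, so a weakening step is expected: a 4.9-fold higher number from compound 3 to compound 4 (0.69 log units; beyond the scatter). Compound 4 is thus estimated at 30000 nM, with a plausible range from 8000 nM to 60000 nM, and a real chance that this assay again returns only a limit.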

Compound 4, half-maximal inhibitory concentration: > 50000 nM
Compound 4: no number, only a limit (the forecaster's own chance of this, stated with the estimate: 45%); middle value at least 1.6-fold (0.22 log units) away from the limit.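

Replacing thiophen-2-yl with quinolin-2-yl, which brings a second aromatic ring and swaps sulfur for nitrogen as the ring hetero atom, gives an at least 8.1-fold higher number from compound 3 to compound 4 (0.91 log units; beyond the scatter) in this assay. Among the compounds shown here, until now, the loss of a readable number at this place had been seen only with the 3-chlorophenyl group of compound 1's close relative, compound 2, and the 5-bromothiophen-2-yl group of compound 1; a group of two aromatic rings containing nitrogen now joins them, leaving thiophen-2-yl as the only group here with an actual number. The steps from compound 1 and compound 2 to compound 4 cannot be read, and these three groups cannot be ranked against one another, because all three compounds report only the same limit: the limit of > 50000 nM in this assay, at which 3 of the 4 values shown sit.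

The compounds shown do not separate the effect of the added ring from that of the changed hetero atom, a question that a pyridin-2-yl group at this place could address. They also leave open whether a furan-2-yl or an unsubstituted phenyl group would give a readable number, and whether any group here could improve on compound 3, at 6100 nM.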